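This account rests on a few compounds, and the source may have more. Where it says the series, first, only, none or still open, it means among the compounds named here.

Working notes on the series. Three analogues sharing one core have been run through an ADME assay on the whole organism (Mus musculus, strain CD1), read by LC-MS, using cassette dosing, with a stated time of 24 h, at a dose of 0.4 mg/kg by the intravenous route; a lower number here means less compound in the circulation, a higher number more compound in the circulation at the dose given. Compound 1 `Cc1cn(-c2cc(CN3CCN(C)CC3)cc(NC(=O)c3ccc(C)c(Nc4nccc(-c5ccccc5)n4)c3)c2)cn1` gives 187 ng.h/mL. Compound 2 `Cc1cn(-c2cc(NC(=O)c3ccc(C)c(Oc4ccccc4)c3)cc(N3CCN(C)CC3)c2)cn1` gives 384 ng.h/mL. Going by the values given here, compound 3 `Cc1cn(-c2cc(NC(=O)c3ccc(C)c(Oc4cccc5ccncc45)c3)cc(N3CCN(C)CC3)c2)cn1` gives 133 ng.h/mL, the lowest of the three numbers; its gap to compound 1 is within the scatter, whereas the one single-point step recorded, a 2.9-fold lower number from compound 2 to compound 3 (0.46 log units; beyond the scatter), lies beyond it.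

Compound 4 `Cc1cn(-c2cc(NC(=O)c3ccc(C)c(C(=O)c4cccc(C#N)c4)c3)cc(N3CCN(C)CC3)c2)cn1` is the next member and has not yet been measured in this assay. It differs from compound 3 in one place: (3-cyanophenyl)carbonyl in place of (isoquinolin-8-yl)oxy on an aromatic carbon.

Among the compounds with values here, no recorded step matches this change. Within the data shown here, the only step available, a 2.9-fold lower number from compound 2 to compound 3 (0.46 log units; beyond the scatter), exchanges one aromatic group for another on the same oxygen and is modest in size; it shows that replacement at this position can move the number beyond the scatter, but it does not carry the aryl ether over to an aryl ketone bearing a nitrile, so its direction cannot simply be transferred. With nothing closer to lean on, the expectation for compound 4 is a number near that of compound 3, with a wide spread in both directions, which means an expected step of a 1.3-fold higher number from compound 3 to compound 4 (0.11 log units; within the scatter).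

The estimate for compound 4 in this assay is therefore 170 ng.h/mL, with a range from 60 ng.h/mL to 480 ng.h/mL.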

Compound 4, area under the concentration-time curve: 83 ng.h/mL
Compound 4: middle estimate off by 2.0-fold (0.31 log units), on the high side; measured number inside the range.
By their numbers in this assay, from the lowest: compounds 4, 3 and 1 (each within the scatter of the next, the first and the last beyond it); then compound 2.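

Read in this assay, the result shows that this position is not tied to an aryl ether: (3-cyanophenyl)carbonyl in place of (isoquinolin-8-yl)oxy gives a 1.6-fold lower number from compound 3 to compound 4 (0.20 log units; within the scatter), so these two groups, which differ in both their link and their aromatic part, cannot be told apart here. Set against phenoxy, the same group gives a 4.6-fold lower number from compound 2 to compound 4 (0.67 log units; beyond the scatter), so among the compounds that differ only at this position, both larger replacements now stand beyond the scatter from compound 2, and none goes against this. No measured evidence accounts for these differences.

The step from phenoxy to (3-cyanophenyl)carbonyl changes the link and the ring substituent at once, so the share of each remains unresolved; a plain benzoyl group and a cyanophenoxy group would separate them. Also open, from the compounds shown here alone, is how the number responds when the aromatic group at this position gives way to a non-aromatic one, such as an aliphatic amine or a carboxylic acid.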